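The source may hold more compounds than are shown below. What is called first, only, known or untested is meant among the compounds shown, and "the series" means these compounds.

Among the measured compounds shown here, compound 1 `COc1ccc(C(=O)Nc2cccc(NC(=O)COc3ccc4c(=O)ccoc4c3)c2)cc1` gives the lower of the two numbers so far: in an assay on isolated protein for inhibition of Rho-associated protein kinase 2 (Homo sapiens), read by scintillation counting, radiometric assay and 33P incorporation, with a stated time of 40 min, in the presence of a further agent that is not named here (a lower number here means a stronger inhibitor, a higher number a weaker inhibitor), compound 1 gives 7 nM, while compound 2 `O=C(COc1ccc2c(=O)ccoc2c1)Nc1cccc(NS(=O)(=O)c2ccc(C(F)(F)F)cc2)c1` gives 6890 nM in this assay, a gap beyond the scatter. Compound 3 `Nc1ccc(C(=O)Nc2cccc(NC(=O)COc3ccc4c(=O)ccoc4c3)c2)cc1` differs from compound 1 by amino in place of methoxy on an aromatic carbon. For the measured compounds named here, no measured pair shows this change, so the step is uncertain; the amino group is expected to leave activity close to that of compound 1, with a small shift, if any, toward a weaker inhibitor. On that basis the step from compound 1 to compound 3 is expected to be a 1.7-fold higher number from compound 1 to compound 3 (0.23 log units; within the scatter). Compound 3 is thus expected to give about 12 nM in this assay, plausibly between 3 nM and 45 nM.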

Compound 3, half-maximal inhibitory concentration: 83 nM
Compound 3: the middle estimate sits 6.9-fold (0.84 log units) below what was measured; measured number above the stated range.
By their numbers in this assay, from the lowest: compound 1; then compound 3; then compound 2.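

In this assay, the place para to a large group on this ring proves sensitive: amino in place of methoxy gives a 12-fold higher number from compound 1 to compound 3 (1.07 log units; beyond the scatter) and so the two groups are not interchangeable here. Among the compounds shown here, this is the first pair differing in one place, so it is the first direct reading of any single change. Nothing measured here explains the rise in the number. Going by these compounds, whether a hydroxyl, a methyl or a dimethylamino group at the same place would track methoxy or amino stays open, as does whether the step would recur on a different core.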